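This account rests on a few compounds, and the source may have more. Where it says the series, first, only, none or still open, it means among the compounds named here.

In an assay on CHO cells for displacement of a labelled ligand from Free fatty acid receptor 1 (Homo sapiens), read by scintillation counting, with a stated time of 90 min, in the presence of a further agent that is not named here (on this read-out higher numbers stand for weaker inhibition and lower numbers for stronger inhibition), compound 2 `O=C(O)CC1COc2cc(OCc3cccc(-c4csc5ccccc45)c3)ccc21` gives 290 nM. For the measured compounds named here, compound 3 `O=C(O)CC1COc2cc(OCc3cccc(-c4ccc5sccc5c4)c3)ccc21` gives 570 nM in this assay, and the only single-point step among the measured compounds, a 2.0-fold higher number from compound 2 to compound 3 (0.29 log units; within the scatter), moves one bicyclic group for another. Compound 1 `Cc1cccc(C)c1-c1cccc(COc2ccc3c(ccn3CC(=O)O)c2)c1` returns a limit rather than a number in this assay, > 10000 nM, as the limit of > 10000 nM in this assay, at which 1 of the 3 values shown sits, records. Among the two compounds with numbers, compound 3 has the higher one, though its distance from compound 2 is within the scatter, so the two cannot be ordered.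

Compound 4 `Cc1ccc(-c2cccc(COc3ccc4c(c3)OCC4CC(=O)O)c2)c(C)c1` differs from compound 3 in one place: 2,4-dimethylphenyl in place of 1-benzothiophen-5-yl on an aromatic carbon. The step from compound 2 to compound 3 concerns the same position, but both of those groups are two-ring systems, whereas the group entering here is a single methylated ring, so that step gives little guidance beyond showing the position tolerates change. Compound 1 carries a methylated single ring on a different core and reaches only a limit, but it differs from compound 4 in more than one place. On that basis a weakening, a 2.6-fold higher number from compound 3 to compound 4 (0.42 log units; beyond the scatter), is expected. Compound 4 is estimated at 1500 nM, within 400 nM to 6000 nM.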

Compound 4, inhibition constant in the Free fatty acid receptor 1 assay: 57 nM
Estimate against measurement, compound 4: 26-fold (1.42 log units) above, and the stated range ends above it.
By their numbers in the Free fatty acid receptor 1 assay, from the lowest: compound 4; then compounds 2 and 3 (each within the scatter of the next). At a limit, above all of these: compound 1.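

In the Free fatty acid receptor 1 assay this position does more than tolerate change: 2,4-dimethylphenyl, a single methylated ring, outperforms both two-ring groups (a 10-fold lower number from compound 3 to compound 4 (1.00 log units; beyond the scatter); a 5.1-fold lower number from compound 2 to compound 4 (0.71 log units; beyond the scatter)), whereas swapping one two-ring group for the other stayed within the scatter (a 2.0-fold higher number from compound 2 to compound 3 (0.29 log units; within the scatter)). The second ring and the sulfur of the 1-benzothiophene groups are therefore not needed for this level of inhibition, and in a physicochemical assay for lipophilicity, measured as octanol-water partition, at pH 7.4 (a lower number here means a more polar compound, a higher number a more lipophilic compound), compound 3 gives 3.97 and compound 4 gives 4.15 so that the same pair stays close (a number 0.18 log units higher from compound 3 to compound 4 (within the scatter)). Nothing measured here explains why the methylated ring does better.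

As far as these compounds go, it remains open which of the two methyl groups accounts for the gain, and whether plain phenyl would keep it. Also open, from the compounds shown here alone, is whether a pyridine ring, or an amine on the phenyl ring, would hold this level of inhibition.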